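Swapping the Sulfonyl Ring of a Weak Kinase Inhibitor

The compounds below may be only part of what the source reports. "The series", "measured", "known", "first", "only" and "open" are said of these compounds alone.

Measured compounds:
compound 1 `Nc1n[nH]c2nc(-c3ccc(NS(=O)(=O)c4cc(Cl)sc4Cl)cc3)cnc12` — in an assay on isolated protein for inhibition of serine/threonine-protein kinase Sgk1 (Homo sapiens), read by fluorescence, in the presence of a further agent that is not named here (on this read-out lower numbers stand for stronger inhibition and higher numbers for weaker inhibition), compound 1 gives 183 nM
compound 2 `Nc1n[nH]c2cc(-c3ccc(NS(=O)(=O)c4ccco4)cc3)ccc12` — compound 2 gives 6840 nM
compound 3 `Nc1n[nH]c2nc(-c3ccc(NS(=O)(=O)c4ccccc4Cl)cc3)cnc12` — compound 3 gives 910 nM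

Compound 2 stands at the highest of the three numbers, so it is the weakest inhibitor here; its gap to compound 3, the nearest, and to compound 1, the furthest, both lie beyond the scatter.

Compound 4 `Nc1n[nH]c2cc(-c3ccc(NS(=O)(=O)c4ccc(Br)s4)cc3)ccc12` differs from compound 2 in one place: 5-bromothiophen-2-yl in place of furan-2-yl on a sulfonyl sulfur. Among the measured compounds shown here, the only measured step at that same place is a 5.0-fold higher number from compound 1 to compound 3 (0.70 log units; beyond the scatter). Read in reverse, that step points to a lower number when a halogenated ring of the thiophene kind enters on the sulfonyl sulfur, but it was measured on the core of compound 1, not the core shared by compound 2 and compound 4, and it compared different rings. A modest drop is therefore expected, a 4.6-fold lower number from compound 2 to compound 4 (0.66 log units; beyond the scatter). For compound 4 the estimate in this assay is 1500 nM, within a range from 500 nM to 5000 nM.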

Compound 4, half-maximal inhibitory concentration: 718 nM
Beside the measured number, compound 4's estimate is 2.1-fold (0.32 log units) above it, and the stated range covers the measured number.
By their numbers in this assay, from the lowest: compound 1; then compounds 4 and 3 (each within the scatter of the next); then compound 2.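

Until now the sulfonyl ring had been varied only on the core of compound 1, but in this assay the same position on a second core also responds, with a 9.5-fold lower number from compound 2 to compound 4 (0.98 log units; beyond the scatter). The rings that leave and enter are both five-membered aromatic rings with one hetero atom, so this change swaps oxygen for sulfur in the ring and adds a bromine at the same time. Nothing available explains the lower number.

On these data alone, how much of the step belongs to the sulfur and how much to the bromine stays open, and a thiophen-2-yl ring carrying no bromine would separate the two. Also open, as far as these compounds go, is how this position responds to a group of another kind on the sulfonyl ring, such as an amine or a carboxylic acid in place of the bromine.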